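This account rests on a few compounds, and the source may have more. Where it says the series, first, only, none or still open, it means among the compounds named here.

Measured so far:
Compound 1 `OC[C@H]1OC(n2cnc3c(Nc4ccccc4)nccc32)[C@H](O)[C@@H]1O` gives 4% in a functional assay (Homo sapiens) for inhibition of Nucleic Acid, tested at 100 uM; on this read-out lower numbers stand for less inhibition and higher numbers for more inhibition at the one concentration tested (going by the name of the read-out).
Compound 2 `[O-][n+]1ccc2c(c1)ncn2C1O[C@H](CO)[C@@H](O)[C@H]1O` gives 5% in this assay.
Compound 3 `OC[C@H]1O[C@@H](n2cnc3cnccc32)[C@H](O)[C@@H]1O` gives 13%; 1% (2 entries) in this assay.

On these numbers compound 1 stands lowest of the two single values, but its nearest neighbour, compound 2, lies within the usual scatter of it, so no order between the two can be read. Compound 3 comes with two entries, (the several entries of compound 3 in this assay, 13%; 1% (2 entries)), rather than one number. Compound 4 `CCNc1nccc2c1ncn2C1O[C@H](CO)[C@@H](O)[C@H]1O` has not yet been measured in this assay; it differs from compound 1 by ethyl in place of phenyl on a nitrogen on an aromatic ring. Among the compounds with values here, no measured step of this kind is available, so no change beyond the scatter is expected, and the step of a number 1 percentage points higher from compound 1 to compound 4 (within the scatter) is expected to be small. Compound 4 is expected to give 5%, within a range from -5% to 15%.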

Compound 4, a percentage reported as inhibition, at one concentration (the size of the read-out at that concentration, not a potency): 4%
Estimate against measurement, compound 4: 1 percentage points above, within the range that was stated.
By their numbers in this assay, from the lowest: compounds 1, 4 and 2 (each within the scatter of the next).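

Putting ethyl in place of phenyl on this nitrogen gives no change at the digits printed from compound 1 to compound 4 (within the scatter) in this assay. This first pair differing in one place shows that swapping the ring for a smaller group without a ring leaves the read-out where it was, though both values are low, so a further loss would be hard to see. Repeat readings can also differ widely: the several entries of compound 3 in this assay, 13%; 1% (2 entries)

On these data alone, whether a longer chain, an amine or a carboxylic acid on this nitrogen would raise the inhibition stays open.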